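Aryl swaps on a hydrazone-urea series and WI-38 cytotoxicity

The compounds below may be only part of what the source reports. "The series", "measured", "known", "first", "only" and "open" are said of these compounds alone.

The measured compounds:
- compound 1 `CN(C)CCn1cnnc1-c1cc(Oc2ccc(NC(=O)N/N=C/c3c[nH]c4ccccc34)cc2F)ccn1`: 3620 nM in an ADME assay on WI-38 cells (Homo sapiens) for cytotoxicity, read by MTT assay, with a stated time of 72 h; a higher number here means a weaker inhibitor, a lower number a stronger inhibitor
- compound 2 `COc1ccc(/C=N/NC(=O)Nc2ccc(Oc3ccnc(-c4nncn4CCN(C)C)c3)c(F)c2)c(OC)c1`: 6630 nM in this assay
- compound 3 `COc1ccc(/C=N/NC(=O)Nc2ccc(Oc3ccnc(-c4nncn4CCN(C)C)c3)c(F)c2)c(OC)c1OC`: "not determined" (no result reported) in this assay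

Going by the values given here, compound 3 carries no number in this assay; it was not determined, so its own standing is unknown, and the only anchors are compound 1 and compound 2. The change to compound 4 `CN(C)CCn1cnnc1-c1cc(Oc2ccc(NC(=O)N/N=C/c3ccccc3O[N+](=O)[O-])cc2F)ccn1` is 2-(nitrooxy)phenyl in place of 2,3,4-trimethoxyphenyl on a carbon with a double bond to nitrogen. Among the compounds with values here, the one measured step that bears on it is the exchange at the same place, a 1.8-fold higher number from compound 1 to compound 2 (0.26 log units; within the scatter), which was within the scatter; both measured values sit close together. Within the data shown here, that step points to an aryl exchange on this carbon shifting this assay little, though only one such step is known and the entering group here differs from both earlier ones, so the uncertainty is wide. Compound 4 is therefore expected to land near the two measured compounds, estimated at 5000 nM with a range of 1500 nM to 16000 nM.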

Compound 4, half-maximal inhibitory concentration: 6860 nM
For compound 4 the middle estimate is 1.4-fold (0.14 log units) below the measured one, within the range that was stated.
By their numbers in this assay, from the lowest: compounds 1, 2 and 4 (each within the scatter of the next).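

In this assay, 2-(nitrooxy)phenyl on the carbon with a double bond to nitrogen gives a 1.0-fold higher number from compound 2 to compound 4 (0.01 log units; within the scatter) against 2,4-dimethoxyphenyl, and a 1.9-fold higher number from compound 1 to compound 4 (0.28 log units; within the scatter) against 1H-indol-3-yl. Where a single exchange was known before, three different aryl groups at this place now lie within the scatter of one another, and none of compounds 1, 2 and 4 goes against that, though the pattern extends no further than these three. Nothing shown offers an explanation for this result.

From the compounds shown here alone, it stays open whether a group other than an aryl ring on this carbon, such as a methyl or a longer chain ending in an amine or a carboxylic acid, would give a value outside this cluster. Plain phenyl, or phenyl carrying a hydroxyl or a nitro group, would show whether the nitrooxy group itself matters in this assay at all.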